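Oxime geometry flip in a piperazinyl pyrimidine series

This account rests on a few compounds, and the source may have more. Where it says the series, first, only, none or still open, it means among the compounds named here.

Measured so far:
compound 1, `O/N=C(/CCN1CCN(c2ccccn2)CC1)c1ccccc1`, 21.7 nM
compound 2, `O/N=C(\CCN1CCN(c2ncccn2)CC1)c1ccccc1`, 39.2 nM

Of the compounds shown here, two have been measured in a functional assay on HEK293 cells with D(4) dopamine receptor (Homo sapiens) as the target, read by FLIPR; a lower number here means that less compound is needed, a higher number that more compound is needed for the effect. Compound 1 gives 21.7 nM. Compound 2 gives 39.2 nM, the highest of the two numbers; its nearest neighbour is compound 1, whose number is lower by an amount that lies within the usual scatter of this assay, so the two values cannot be told apart.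

The next compound is compound 3, `O/N=C(/CCN1CCN(c2ncccn2)CC1)c1ccccc1`. Compared with compound 2, (the two compounds have the same atoms and bonds and differ only in configuration as drawn: 1 of 1 stereo elements differ; a double bond is drawn E in compound 2 and Z in compound 3). Nothing is added and nothing is removed; only the drawn arrangement about the oxime double bond changes.

For the measured compounds named here, no measured pair in this set shows what such a change of geometry does in this assay, so there is no step to lean on. The expectation is a change of modest size at most, in either direction, and quite possibly none beyond the scatter; the step from compound 2 to compound 3 is estimated as a 1.3-fold lower number from compound 2 to compound 3 (0.12 log units; within the scatter). Compound 3 is therefore expected to give about 30 nM, within a range of 8 nM to 120 nM.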

Compound 3, half-maximal effective concentration: 69 nM
Estimate against measurement, compound 3: 2.3-fold (0.36 log units) below, and the stated range covers the measured number.
By their numbers in this assay, from the lowest: compounds 1, 2 and 3 (each within the scatter of the next, the first and the last beyond it).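

In this assay, reversing the geometry of the oxime double bond gives a 1.8-fold higher number from compound 2 to compound 3 (0.25 log units; within the scatter), so this change produces no difference that can be separated from the scatter, and the comparison is a clean one because nothing else changes: the fact that compounds 2 and 3 differ only in the configuration as drawn. With the oxime drawn the same way, pyrimidin-2-yl in place of pyridin-2-yl on an amine nitrogen in a ring gives a 3.2-fold higher number from compound 1 to compound 3 (0.50 log units; beyond the scatter), a modest step and the first in this set to clear the scatter. Of the two single changes now visible, only the exchange of rings moves the number beyond the scatter, although this rests on one pair for each change.

As far as these compounds go, it remains open whether flipping the oxime has a similarly small effect when pyridin-2-yl is the ring on that nitrogen, and whether the exchange of rings gives a step of similar size with the other oxime geometry. These compounds also do not show what a phenyl ring in place of pyrimidin-2-yl, or a longer chain in place of the present one, would do in this assay.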